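The source may report more compounds than this note shows. Statements on the series, on what has been measured and on what is new or still open speak of the compounds shown alone.

Compound 1 `Cc1cccc2[nH]c(-c3n[nH]c4ncc(-c5cncc6ccccc56)cc34)nc12` is the starting point of this account, yet in an assay on isolated protein for inhibition of proto-oncogene tyrosine-protein kinase receptor Ret (Homo sapiens) (a lower number here means a stronger inhibitor, a higher number a weaker inhibitor), compound 1 stands as "not determined" (no result reported); nothing on its own potency is known. Two relatives of the shared core carry numbers. Compound 2 `COCc1cccc2[nH]c(-c3n[nH]c4ncc(-c5cccnc5)cc34)nc12` gives 1100 nM in this assay, and compound 3 `CN1CCN(c2ccc3[nH]c(-c4n[nH]c5ncc(-c6cncc7ccccc67)cc45)nc3c2)CC1` gives 1000 nM; these two values lie within the scatter of each other, so no order between them can be stated. The untested compound 4 `CCN(CC)C(=O)c1cccc2[nH]c(-c3n[nH]c4ncc(-c5cncc6ccccc56)cc34)nc12` differs from compound 1 in one place: diethylcarbamoyl in place of methyl on an aromatic carbon. Going by the values given here, no step between measured compounds maps this change, so its size and direction cannot be read from the data; the expectation rests only on the level set by compound 2 and compound 3. On that basis compound 4 is expected to come out in this assay near 800 nM, with a range from 150 nM to 4000 nM.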

Compound 4, half-maximal inhibitory concentration: 1230 nM
Beside the measured number, compound 4's estimate is 1.5-fold (0.19 log units) below it, and the stated range covers the measured number.
By their numbers in this assay, from the lowest: compounds 3, 2 and 4 (each within the scatter of the next).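

The result for compound 4 yields no new step, as neither compound 1 nor any other compound shown forms a readable one-place pair with it. From the compounds shown here alone, the effect of diethylcarbamoyl in place of methyl on the shared core remains open. No evidence shown bears on this result.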